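Chloro on the Styryl Ring of a Dithiocarbamate Chalcone

A few compounds are considered here, and "the series" means these few. Any claim that something is new, unique, unknown or untested is made for them only; others in the source may bear on it.

Compound 3 `O=C(CSC(=S)N[C@H]1CCOC1=O)Nc1ccc(C(=O)/C=C/c2ccccc2)cc1` carries the dithiocarbamate arm on the anilide and an unsubstituted 2-phenylethenyl group on the carbonyl carbon. In a functional assay on EC9706 cells (Homo sapiens) for cytotoxicity, read by MTT assay, with a stated time of 72 h (on this read-out higher numbers stand for weaker inhibition and lower numbers for stronger inhibition), compound 3 gives 44900 nM, the highest of the two numbers recorded in the series. Compound 2 `O=C(CCl)Nc1ccc(C(=O)/C=C/c2ccccc2Cl)cc1`, which pairs a chloroacetamide with the 2-(2-chlorophenyl)ethenyl ketone, gives 6980 nM in this assay. Compound 1 `CC(=O)c1ccc(NC(=O)CSC(=S)N[C@H]2CCOC2=O)cc1` is the acetyl analogue of compound 3. In this assay compound 1 returns only a limit, namely > 128000 nM. Among the measured compounds shown here, the one measured step, an at least 2.8-fold lower number from compound 1 to compound 3 (0.45 log units; beyond the scatter), can be given only as a bound because the limit of > 128000 nM in this assay, at which 1 of the 3 values shown sits, fixes one end of it.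

Compound 4 `O=C(CSC(=S)N[C@H]1CCOC1=O)Nc1ccc(C(=O)/C=C/c2ccccc2Cl)cc1` differs from compound 3 by chloro in place of hydrogen on an aromatic carbon. For the measured compounds named here, no measured step alters this position on its own: compound 2 and compound 3 differ in two places, so their two values show only that the compound bearing the chloro sits at a lower number, without isolating the contribution of that chloro. On that weak footing a lowering no larger than modest is expected for compound 4, the step of a 2.2-fold lower number from compound 3 to compound 4 (0.35 log units; beyond the scatter) being the estimated size. Compound 4 is therefore estimated at 20000 nM in this assay, within a range from 7000 nM to 60000 nM.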

Compound 4, half-maximal inhibitory concentration: 34100 nM
Beside the measured number, compound 4's estimate is 1.7-fold (0.23 log units) below it, and the stated range covers the measured number.
By their numbers in this assay, from the lowest: compound 2; then compounds 4 and 3 (each within the scatter of the next). At a limit, above all of these: compound 1.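

In this assay, chloro in place of hydrogen on this aromatic carbon, ortho to a large group, can now be read alone and gives a 1.3-fold lower number from compound 3 to compound 4 (0.12 log units; within the scatter), so with the dithiocarbamate arm in place the change from phenyl to 2-chlorophenyl leaves no readable difference. With the 2-(2-chlorophenyl)ethenyl group held constant, the group of 10 heavy atoms in place of one chlorine atom on the saturated chain carbon gives a 4.9-fold higher number from compound 2 to compound 4 (0.69 log units; beyond the scatter), which places a gap beyond the scatter at the chain end of the anilide and not at the ring chloro. The 2-(2-chlorophenyl)ethenyl group in place of methyl on the carbonyl carbon gives an at least 3.7-fold lower number from compound 1 to compound 4 (0.57 log units; beyond the scatter), a step that stands only as a bound: the limit of > 128000 nM in this assay, at which 1 of the 4 values shown sits.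

The compounds shown hold no pair that isolates the ring chloro on the chloroacetamide end, so it remains open whether this position counts there when the dithiocarbamate arm is absent. Also open, as far as these compounds go, is how a methoxy group or a dimethylamino group on the same aromatic carbon would read with either chain end.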